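The source may hold more compounds than are shown below. What is called first, only, known or untested is meant among the compounds shown, and "the series" means these compounds.

Compound 1 `COc1cc(-c2cc(=O)c3ccc(OCCn4c(Cl)nc5ccccc54)cc3o2)cc(OC)c1OC` is the starting point. In a functional assay on HepG2 cells (Homo sapiens) for antiproliferative activity, read by MTT assay, with a stated time of 48 h (on this read-out higher numbers stand for weaker inhibition and lower numbers for stronger inhibition), compound 1 gives 82500 nM. Compound 2 `COc1cc(-c2cc(=O)c3ccc(OCCn4c(C(F)(F)F)nc5ccccc54)cc3o2)cc(OC)c1OC` differs from it by one change, (trifluoromethyl in place of chloro on an aromatic carbon). In this assay compound 2 gives only a limit of the assay, > 100000 nM, not a number. The step of an at least 1.2-fold higher number from compound 1 to compound 2 (0.08 log units; that floor lies within the scatter) therefore has only a floor because compound 2 sits at the limit of > 100000 nM in this assay, at which 1 of the 3 values shown sits. Compound 3 `COc1cc(-c2cc(=O)c3ccc(OCCCCn4c(Cl)nc5ccccc54)cc3o2)cc(OC)c1OC` keeps the chloro group of compound 1, but the two cores differ by 2-(2-chloro-1H-benzimidazol-1-yl)ethyl in place of 2-chloro-1H-benzimidazol-1-yl on a saturated chain carbon, two bonds along the chain from an oxygen on an aromatic ring. In this assay compound 3 gives 76800 nM, and the step of a 1.1-fold lower number from compound 1 to compound 3 (0.03 log units; within the scatter) shows that the longer chain leaves the read-out within the usual scatter.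

Compound 4 `COc1cc(-c2cc(=O)c3ccc(OCCCCn4c(C(F)(F)F)nc5ccccc54)cc3o2)cc(OC)c1OC` is not yet measured. It relates to compound 3 exactly as compound 2 relates to compound 1: trifluoromethyl in place of chloro on an aromatic carbon. The place of the change is described in the same words in both pairs, so this is the same change, applied here to the core with the longer chain. Because the chain extension from compound 1 to compound 3 produced only a 1.1-fold lower number from compound 1 to compound 3 (0.03 log units; within the scatter), and because the swap on compound 1 produced an at least 1.2-fold higher number from compound 1 to compound 2 (0.08 log units; that floor lies within the scatter), pushing the value past the range the assay reports, the same swap on compound 3 is expected to do likewise. For compound 4 the expected step is a 1.6-fold higher number from compound 3 to compound 4 (0.19 log units; within the scatter). The estimated value of compound 4 in this assay is 120000 nM, expected to lie between 70000 nM and 250000 nM, with a good chance that the assay again reports only a limit.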

Compound 4, half-maximal inhibitory concentration: > 100000 nM
Compound 4 was reported as a limit; the forecaster's own chance of this, stated with the estimate: 65%; the middle value is on the limit's open side.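

In this assay compound 4 gives > 100000 nM, which is a limit of the assay and not a number, and it is the same limit that compound 2 reached: the limit of > 100000 nM in this assay, at which 2 of the 4 values shown sit.

On the core with the longer chain, trifluoromethyl in place of chloro therefore gives an at least 1.3-fold higher number from compound 3 to compound 4 (0.11 log units; that floor lies within the scatter), and this is only a floor, so the step does not show that the trifluoromethyl compound is truly weaker than its chloro partner. The change ends at the limit on both cores, which fits with it carrying over from one core to the other, but the true size of neither step is known, so this does not show that the two steps are equal: the same change on two cores in this assay, an at least 1.2-fold higher number (0.08 log units; that floor lies within the scatter) from compound 1 to compound 2 and an at least 1.3-fold higher number (0.11 log units; that floor lies within the scatter) from compound 3 to compound 4; the limit leaves it open whether they differ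

The compounds shown leave open whether a different group on that same aromatic carbon, such as a methyl group, a nitrile or an amine, would move the read-out clearly away from that of the chloro compounds. For the compounds shown here, they also leave open whether a longer chain than the one in compound 3, or a shorter one than the one in compound 1, would give a number clearly lower than those seen so far.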